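A Sulfonamide Replaces a Methyl on a Non-Toxic Core

The compounds below may be only part of what the source reports. "The series", "measured", "known", "first", "only" and "open" are said of these compounds alone.

Of the compounds shown here, three built on a shared core have been tested in a functional assay on HEK293 cells (Homo sapiens) for cytotoxicity; on this read-out higher numbers stand for lower toxicity in this test and lower numbers for higher toxicity in this test. Compound 1 `COc1ccc([C@H]2CC(=O)N(Cc3cccc(N)c3)C2)cc1OC1CCCC1` gives only a limit of the assay there, > 10000 nM. Compound 2 `COc1ccc([C@H]2CC(=O)N(c3ccc(C)c(N)c3)C2)cc1OC1CCCC1` likewise gives only a limit, > 10000 nM. Compound 3 `COc1ccc([C@H]2CC(=O)N(c3cccc(C)c3)C2)cc1OC1CCCC1` also reaches only a limit in this assay, > 10000 nM. Because all three values sit at the limit of > 10000 nM in this assay, at which 3 of the 3 values shown sit, the steps between them cannot be read: a step that the two limits leave unreadable from compound 1 to compound 2, a step that the two limits leave unreadable from compound 1 to compound 3 and a step that the two limits leave unreadable from compound 2 to compound 3 give no usable size or direction. Compound 3 thus stands at the same limit as the other two. Compound 4 `COc1ccc([C@H]2CC(=O)N(c3cccc(NS(=O)(=O)c4ccccc4Cl)c3)C2)cc1OC1CCCC1` differs from compound 3 in one place: ((2-chlorophenyl)sulfonyl)amino in place of methyl on an aromatic carbon. Within the data shown here, no measured step involves such an exchange, and the measured steps show only that three different groups on the amide-type nitrogen in a ring all left toxicity undetected in this assay. The expected step is therefore a step that the limit leaves unreadable from compound 3 to compound 4, with compound 4 expected to remain at the limit. Compound 4 is estimated at 15000 nM, in a range from 7000 nM to 40000 nM.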

Compound 4, half-maximal cytotoxic concentration: > 10000 nM
Compound 4 gave a limit, no number (the forecaster's own chance of this, stated with the estimate: 85%); the middle value does not contradict the limit.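

In this assay compound 4 gives only a limit, and the step from compound 3 to compound 4 cannot be read, because both compounds stand at the same limit: the limit of > 10000 nM in this assay, at which 4 of the 4 values shown sit. Still open, on these data alone, is whether any of these four compounds shows measurable toxicity to these cells, and at what concentration.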